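Bromo to iodo at the limit of the assay

This account rests on a few compounds, and the source may have more. Where it says the series, first, only, none or still open, it means among the compounds named here.

Values in an ADME assay on MCF-10A cells (Homo sapiens) for inhibition, with a stated time of 48 h (on this read-out lower numbers stand for stronger inhibition and higher numbers for weaker inhibition), so far
Compound 1 (`O=C(Nc1ccc(Cl)cc1)N1CCC[C@H]1c1nc(-c2ccccc2F)no1`) gives > 50000 nM
Compound 2 (`O=C(Nc1ccc(Cl)cc1)N1CCC[C@H]1c1nc(-c2ccc(Br)cc2)no1`) gives > 50000 nM
Compound 3 (`O=C(Nc1ccc(Cl)cc1)N1CCC[C@H]1c1nc(-c2ccc(I)cc2)no1`) is not yet measured

Compound 2 stands at > 50000 nM as a limit of the assay and not as a number. Compound 1 likewise gives > 50000 nM as a limit. Compound 3 carries iodo in place of bromo on an aromatic carbon, para to a large group (iodo in place of bromo on an aromatic carbon). Within the data shown here, the one measured step that bears on this change is a step that the two limits leave unreadable from compound 1 to compound 2 and it offers no size to carry over. The evidence consists of a single limit (the limit of > 50000 nM in this assay, at which 2 of the 2 values shown sit) and neither measured compound has given a number. No step beyond the scatter is therefore expected in this assay in either direction. The expectation rests on compound 2 with its limit of > 50000 nM as the only anchor. The expected change is a number no higher from compound 2 to compound 3 (the limit leaves the size open) in size, and the result may well arrive as a limit again. For compound 3 the estimated value is 50000 nM with an expected range from 25000 nM to 100000 nM in this assay for now.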

Compound 3, half-maximal inhibitory concentration: > 50000 nM
Compound 3 gave a limit, no number; the forecaster's own chance of this, stated with the estimate: 85%; the middle value lies on the limit itself.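

Compound 3, like compound 1 and compound 2, gives a limit and not a number in this assay, so no step can be read among these three compounds: the limit of > 50000 nM in this assay, at which 3 of the 3 values shown sit.

The compounds shown leave open what number, if any, each of the three would give in this assay, and whether these changes on the aromatic ring alter it at all.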